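Aryl change on the benzylic sulfur: compound 3 to compound 4

This account rests on a few compounds, and the source may have more. Where it says the series, first, only, none or still open, it means among the compounds named here.

The compounds share one core and differ in the aryl group on a saturated chain carbon bound to a sulfur. In a functional assay on MCF7 cells (Homo sapiens) for cytotoxicity, read by MTT assay, with a stated time of 72 h (a lower number here means a stronger inhibitor, a higher number a weaker inhibitor), compound 1 `Cc1cc(S(=O)(=O)/N=C(\N)n2nccc2-c2ccccc2)c(SCc2ccccc2Cl)cc1Cl` gives 24000 nM. Compound 3 `Cc1cccc(CSc2cc(Cl)c(C)cc2S(=O)(=O)/N=C(\N)n2nccc2-c2ccccc2)c1` gives 47000 nM, and compound 2 `Cc1cc(-c2ccccc2)n(/C(N)=N/S(=O)(=O)c2cc(C)c(Cl)cc2SCc2ccccc2C(F)(F)F)n1` gives 101000 nM. Compound 3 stands second highest of the three numbers: its nearest neighbour is compound 1, within the scatter, and its furthest is compound 2, beyond the scatter. For the measured compounds named here, no single-change step connects compound 2 with compound 3, so for that pair only the two values themselves are compared.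

Going by the values given here, the one measured step that bears on the aryl group is a 2.0-fold higher number from compound 1 to compound 3 (0.29 log units; within the scatter). Compound 4 `Cc1cc(S(=O)(=O)/N=C(\N)n2nccc2-c2ccccc2)c(SCc2ccc(C(F)(F)F)cc2)cc1Cl` differs from compound 3 as follows: 4-(trifluoromethyl)phenyl in place of 3-methylphenyl on a saturated chain carbon bound to a sulfur. With a single relevant step, and that one within the scatter, the expectation for compound 4 in this assay is no movement beyond the scatter, estimated as a 1.1-fold higher number from compound 3 to compound 4 (0.03 log units; within the scatter). Compound 4 is estimated at 50000 nM, with a range from 20000 nM to 125000 nM.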

Compound 4, half-maximal inhibitory concentration: 25000 nM
Compound 4: middle estimate off by 2.0-fold (0.30 log units), on the high side, and the stated range covers the measured number.
By their numbers in this assay, from the lowest: compounds 1, 4 and 3 (each within the scatter of the next); then compound 2.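

In this assay the saturated chain carbon bound to a sulfur now carries a third aryl group, and 4-(trifluoromethyl)phenyl stays within the scatter against both 3-methylphenyl (a 1.9-fold lower number from compound 3 to compound 4 (0.27 log units; within the scatter)) and 2-chlorophenyl (a 1.0-fold higher number from compound 1 to compound 4 (0.02 log units; within the scatter)). With the earlier step (a 2.0-fold higher number from compound 1 to compound 3 (0.29 log units; within the scatter)), no step among these three aryl groups passes the scatter, even though the entering group holds 10 heavy atoms against 7 for 3-methylphenyl. Nothing on hand offers a cause for these steps.

Still open, as far as these compounds go, is whether a carboxylic acid or an amine on the aryl group, or a longer chain on the sulfur, would give a step beyond the scatter. For the compounds shown here, compound 2 has no single-change step to compound 4, so what its value means for this position also stays open.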